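This account rests on a few compounds, and the source may have more. Where it says the series, first, only, none or still open, it means among the compounds named here.

Measured so far, in a functional assay on HepG2 cells (Homo sapiens) for antiproliferative activity, read by CCK-8 assay, with a stated time of 72 h; on this read-out higher numbers stand for weaker inhibition and lower numbers for stronger inhibition:

Compound 1 `O=C(Nc1cccc(-c2oc3cc(-c4ccc(F)cc4)ccc3c(=O)c2O)c1)c1ccc(Cl)cc1` gives 11000 nM.
Compound 2 `O=C(Nc1cccc(-c2oc3cc(-c4ccc(F)cc4)ccc3c(=O)c2O)c1)c1ccc(C(F)(F)F)cc1` gives 42700 nM.
Compound 3 `O=C(Nc1cccc(-c2oc3cc(-c4ccc(F)cc4)ccc3c(=O)c2O)c1)c1ccc(Br)cc1` gives 13900 nM.

Compound 3 stands second highest of the three; its value and that of compound 1 lie within the usual scatter of each other, while compound 2 is clearly higher, as the step of a 3.1-fold lower number from compound 2 to compound 3 (0.49 log units; beyond the scatter) shows. Compound 4 `O=C(Nc1cccc(-c2oc3cc(-c4ccc(F)cc4)ccc3c(=O)c2O)c1)c1cccc(F)c1` differs from compound 3 in one place: 3-fluorophenyl in place of 4-bromophenyl on a carbonyl carbon. For the measured compounds named here, no measured step changes both the substituent and its place on that ring. The nearest guides are a 1.3-fold higher number from compound 1 to compound 3 (0.10 log units; within the scatter) and a 3.9-fold higher number from compound 1 to compound 2 (0.59 log units; beyond the scatter): one substituent swap on that ring barely moved this assay, the other raised the number modestly. A small step is therefore expected, a 1.2-fold lower number from compound 3 to compound 4 (0.06 log units; within the scatter), with no clear direction beyond the scatter. Compound 4 is estimated at 12000 nM, between 5000 nM and 30000 nM.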

Compound 4, half-maximal inhibitory concentration: 15500 nM
Compound 4: middle estimate off by 1.3-fold (0.11 log units), on the low side, within the range that was stated.
By their numbers in this assay, from the lowest: compounds 1, 3 and 4 (each within the scatter of the next); then compound 2.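

Replacing 4-bromophenyl with 3-fluorophenyl on the carbonyl carbon changes both the halogen and where it sits on that ring, yet this assay shows a 1.1-fold higher number from compound 3 to compound 4 (0.05 log units; within the scatter) and a 1.4-fold higher number from compound 1 to compound 4 (0.15 log units; within the scatter), so neither change separates compound 4 from these two compounds. Compound 2 remains apart, with a 2.8-fold lower number from compound 2 to compound 4 (0.44 log units; beyond the scatter). Nothing measured here offers an explanation for this.

Still open, from the compounds shown here alone, is whether an amine or a carboxylic acid on that ring would take the number clearly below those of the halogen compounds.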